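Adding an Isopropyl Group to a Primary Sulfonamide

The source may report more compounds than this note shows. Statements on the series, on what has been measured and on what is new or still open speak of the compounds shown alone.

Of the compounds shown here, two have so far been measured in a functional assay on the whole organism (strain STD-dd) with Mus musculus as the target, in the maximal electroshock model, with a stated time of 2 h; on this read-out higher numbers stand for an effect only at larger amounts of compound and lower numbers for an effect already at smaller amounts. Compound 1 `CN1CCN(S(=O)(=O)Cc2noc3ccccc23)CC1` carries a sulfonamide whose nitrogen is built into a ring, and in this assay compound 1 gives 57 mg/kg. Compound 2 `NS(=O)(=O)Cc1noc2ccc(F)cc12` carries a primary sulfonamide on a fluorinated core, and in this assay compound 2 gives 15 mg/kg, the lowest of the two numbers; its gap to compound 1 lies beyond the usual scatter. Among the measured compounds shown here, because the two compounds differ in more than one place, no single step can be drawn between them; their values only show which one acts at the smaller amount.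

Compound 3 `CC(C)NS(=O)(=O)Cc1noc2ccc(F)cc12` has not yet been measured. It differs from compound 2 in one place: isopropyl in place of hydrogen on a sulfonamide nitrogen. Cut one bond further out, the change reads amino to isopropylamino.

For the measured compounds named here, no measured pair shows this exact change. Going by the values given here, the only guide is that compound 1, with a substituted sulfonamide nitrogen, gives 57 mg/kg, while compound 2, with an open one, gives 15 mg/kg. On that basis a modest rise is expected, a step of a 2.0-fold higher number from compound 2 to compound 3 (0.30 log units; within the scatter), sitting near the edge of the scatter. Compound 3 is therefore estimated to give 30 mg/kg, within a range of 12 mg/kg to 80 mg/kg.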

Compound 3, dose for half-maximal effect: 38 mg/kg
Estimate against measurement, compound 3: 1.3-fold (0.10 log units) below; low and high end bracket the measured number.
By their numbers in this assay, from the lowest: compound 2; then compounds 3 and 1 (each within the scatter of the next).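

In this assay, among the compounds shown here, isopropyl in place of hydrogen on a sulfonamide nitrogen gives a 2.5-fold higher number from compound 2 to compound 3 (0.40 log units; beyond the scatter), the first step in this set that rests on a single change with the rest of the molecule held the same. It shows that this nitrogen can carry a carbon group and the compound still acts in this model, while the open primary sulfonamide of compound 2 acts at the smaller amount. Nothing available here explains why the number rises with this change.

A single step cannot show how the number follows the size or shape of the group: a methyl, a cyclopropyl or a longer chain on the same nitrogen would each add a further point on the same core. Compound 1 differs from compound 2 in more than one place, so the contribution of its ring-bound sulfonamide nitrogen and that of the fluorine on the core of compound 2 cannot be told apart.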